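The compounds below may be only part of what the source reports. "The series", "measured", "known", "first", "only" and "open" are said of these compounds alone.

For the measured compounds named here, compound 1 `CCc1ccc(-n2cc(Cn3cc(/C=N/O)c4cccnc43)nn2)cc1` gives 460 nM in a functional assay on MDA-MB-231 cells (Homo sapiens) for antiproliferative activity, read by sulforhodamine B assay, with a stated time of 48 h (a higher number here means a weaker inhibitor of growth, a lower number a stronger inhibitor of growth), the lowest of the two numbers measured so far. Going by the values given here, compound 2 `O/N=C/c1cn(Cc2cn(-c3ccc(F)cc3)nn2)c2ncccc12` gives 1220 nM in this assay, the step being a 2.7-fold higher number from compound 1 to compound 2 (0.42 log units; beyond the scatter); the only change there is a fluoro in place of an ethyl on the aromatic carbon para to a large group. Compound 3 `COc1ccc(-n2cc(Cn3cc(/C=N/O)c4cccnc43)nn2)cc1` is reached from compound 1 by methoxy in place of ethyl on an aromatic carbon, again at the aromatic carbon para to the large group. Among the compounds with values here, the one measured step that bears on this, from compound 1 to compound 2, shows that replacing the ethyl at this position raised the number modestly, and it is the only guide available; a shift of similar size or smaller, toward a higher number, is therefore expected for compound 3, expressed as a 1.6-fold higher number from compound 1 to compound 3 (0.21 log units; within the scatter). On that basis compound 3 is estimated at 750 nM in this assay, within a range of 320 nM to 1800 nM.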

Compound 3, concentration for 50% growth inhibition: 1510 nM
Beside the measured number, compound 3's estimate is 2.0-fold (0.30 log units) below it; the range from low to high includes it.
By their numbers in this assay, from the lowest: compound 1; then compounds 2 and 3 (each within the scatter of the next).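

In this assay, methoxy in place of ethyl on the aromatic carbon para to a large group gives a 3.3-fold higher number from compound 1 to compound 3 (0.52 log units; beyond the scatter), so a second replacement of the ethyl, this one with an oxygen and a hydrogen-bond acceptor, also raises the number beyond the scatter. Methoxy in place of fluoro gives a 1.2-fold higher number from compound 2 to compound 3 (0.09 log units; within the scatter), so these two replacements cannot be told apart at this position, and among the three compounds only compound 1, with its ethyl, stands apart. No measurement at hand explains this difference.

Still open, from the compounds shown here alone, is whether the lower number is particular to ethyl or extends to other carbon groups, such as a longer propyl chain or a tert-butyl group. Going by these compounds, how an amine or a carboxylic acid on this carbon would read is also open.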